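Chloro substitution on the sulfonamide series: compound 4

The compounds below may be only part of what the source reports. "The series", "measured", "known", "first", "only" and "open" are said of these compounds alone.

Compound 1 `O=S(=O)(Nc1ccccc1)c1ccccc1` is the parent of this small set. Among the measured compounds shown here, in an ADME assay, compound 1 gives 9.1, the highest of the three numbers so far. Compound 2 `O=[N+]([O-])c1cccc(NS(=O)(=O)c2ccccc2)c1` gives 7.93; compound 3 `O=[N+]([O-])c1cccc(NS(=O)(=O)c2ccc(Cl)cc2)c1` gives 7.51. The two cores differ as described by hydrogen in place of nitro on an aromatic carbon, and the step of a number 1.17 log units lower from compound 1 to compound 2 (beyond the scatter) is the larger of the two measured steps. The change of interest is chloro in place of hydrogen on an aromatic carbon, made twice among these compounds: once as chloro in place of hydrogen on an aromatic carbon, where it gave the step of a number 0.42 log units lower from compound 2 to compound 3 (beyond the scatter), and once as chloro in place of hydrogen on an aromatic carbon, leading to compound 4 `O=S(=O)(Nc1ccc(Cl)cc1)c1ccccc1`, which has not yet been measured in this assay. The two place descriptions match word for word, so the change is taken as the same. On that basis the step from compound 1 to compound 4 in this assay is expected to be about a number 0.45 log units lower from compound 1 to compound 4 (beyond the scatter), close in size to the measured one from compound 2 to compound 3. Compound 4 is therefore estimated at 8.65, with a range from 8.3 to 9, pending the measurement.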

Compound 4, acid dissociation constant: 8.75
Beside the measured number, compound 4's estimate is 0.10 log units below it; the range from low to high includes it.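

In this assay, chloro in place of hydrogen on an aromatic carbon gives a number 0.35 log units lower from compound 1 to compound 4 (beyond the scatter), and this step agrees with the one already seen on the core of compound 2: the same change on two cores in this assay, a number 0.42 log units lower (beyond the scatter) from compound 2 to compound 3 and a number 0.35 log units lower (beyond the scatter) from compound 1 to compound 4, 0.07 log units apart, within the scatter of two such steps. On these two cores, one with a nitro group and one without, the change therefore carries over with much the same size. Among the compounds shown here, this does not establish a general rule, since the agreement rests on only two pairs, the chloro group does not stand on the same six-membered aromatic ring in compound 3 and compound 4, and the match says nothing about why the steps are alike.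

The compounds shown leave open whether the same step would hold on cores carrying other groups, such as an amine or a carboxylic acid. They also leave open whether a group other than chloro, such as methoxy or trifluoromethyl, would carry over between these cores as consistently.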